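Working notes: isobutyl to (pyridin-3-yl)methyl from compound 3

A few compounds are considered here, and "the series" means these few. Any claim that something is new, unique, unknown or untested is made for them only; others in the source may bear on it.

Measured in a functional assay on L1210 cells (Mus musculus) for inhibition; a higher number here means a weaker inhibitor, a lower number a stronger inhibitor:
- compound 1 `CC(C)CN(CC(=O)N(CC(C)C)NC(=O)OCc1ccccc1)NC(=O)CNNC(=O)CBr`: 7600 nM
- compound 2 `CC(C)CN(CC(=O)N(CC(C)C)NC(=O)OCc1ccccc1)/N=C/c1ccccc1B(O)O`: 16200 nM
- compound 3 `CC(C)CN(CC(=O)N(CC(C)C)NC(=O)OCc1ccccc1)/N=C/c1cccc(B(O)O)c1`: 21200 nM

Compound 3 gives 21200 nM and sits with compound 2 at the upper end of the three numbers. The steps are a 1.3-fold higher number from compound 2 to compound 3 (0.12 log units; within the scatter) and a 2.8-fold higher number from compound 1 to compound 3 (0.45 log units; beyond the scatter).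

Compound 4 `CC(C)CN(CC(=O)N(Cc1cccnc1)NC(=O)OCc1ccccc1)/N=C/c1cccc(B(O)O)c1` carries one change: pyridin-3-yl in place of isopropyl on a saturated chain carbon bound to an amide-type nitrogen. Cut one bond further out, this reads isobutyl to (pyridin-3-yl)methyl. Going by the values given here, no measured step touches this place. The nearest evidence is indirect: a 2.1-fold higher number from compound 1 to compound 2 (0.33 log units; beyond the scatter) and a 2.8-fold higher number from compound 1 to compound 3 (0.45 log units; beyond the scatter), both modest and made at another group. No step beyond the scatter is therefore expected in this assay, with low confidence. The expected step is a 1.2-fold lower number from compound 3 to compound 4 (0.07 log units; within the scatter). For compound 4 the estimated value is 18000 nM, with an expected range of 7000 nM to 45000 nM.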

Compound 4, half-maximal inhibitory concentration: 41600 nM
Compound 4: middle estimate off by 2.3-fold (0.36 log units), on the low side, within the range that was stated.
By their numbers in this assay, from the lowest: compound 1; then compounds 2, 3 and 4 (each within the scatter of the next, the first and the last beyond it).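

In this assay, pyridin-3-yl in place of isopropyl on a saturated chain carbon bound to an amide-type nitrogen gives a 2.0-fold higher number from compound 3 to compound 4 (0.29 log units; within the scatter). Going by these compounds alone, this is the first reading at this position, and it shows that a six-membered aromatic ring with one ring nitrogen can replace the branched alkyl end without a step beyond the scatter. Nothing on hand explains the size of this step. From the compounds shown here alone, whether a simple amine, a carboxylic acid or a longer alkyl chain at this place would give a step beyond the scatter stays open. Also open, going by these compounds, is whether the same change would read alike on compound 2.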